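A Methoxyphenyl in Place of Bromohydroxyphenyl on the Amide

This account rests on a few compounds, and the source may have more. Where it says the series, first, only, none or still open, it means among the compounds named here.

This piece follows one change within a small set of amides tested in an assay for inhibition of HSP60/HSP10 (Homo sapiens), with a stated time of 60 min; a higher number here means a weaker inhibitor, a lower number a stronger inhibitor. Compound 1 `O=C(Nc1ccccc1)c1cccc(Br)c1` is the simplest member. In this assay compound 1 reaches only the limit of the assay, > 100000 nM, which is not a number. Compound 2 `O=C(Nc1ccc(Sc2nc3ccccc3s2)c(Cl)c1)c1cccc(Br)c1O` carries a larger group on the amide nitrogen and a 3-bromo-2-hydroxyphenyl on the carbonyl carbon. In this assay compound 2 gives 6900 nM. Going by the values given here, this is the only number in the set. The other entry, that of compound 1, is a limit (the limit of > 100000 nM in this assay, at which 1 of the 2 values shown sits). The next compound, compound 3 `COc1ccccc1C(=O)Nc1ccc(Sc2nc3ccccc3s2)c(Cl)c1`, keeps everything except the ring on the carbonyl side: 2-methoxyphenyl in place of 3-bromo-2-hydroxyphenyl on a carbonyl carbon. Among the compounds with values here, no measured pair differs in just this place, so the size of this step cannot be read from the data. The hydroxyl and the bromine are lost and a methoxy takes their place, and compound 3 is expected to come out weaker, with a step of a 2.9-fold higher number from compound 2 to compound 3 (0.46 log units; beyond the scatter) expected to exceed the usual scatter. For compound 3 the estimate in this assay is 20000 nM, within a range from 7000 nM to 60000 nM.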

Compound 3, half-maximal inhibitory concentration: > 100000 nM
Compound 3: a limit, no number; the forecaster's own chance of this, stated with the estimate: 25%; at least 5.0-fold (0.69 log units) between middle value and limit.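

Putting 2-methoxyphenyl in place of 3-bromo-2-hydroxyphenyl on the carbonyl carbon, with the rest of the molecule unchanged, has a large effect in this assay (an at least 14-fold higher number from compound 2 to compound 3 (1.16 log units; beyond the scatter)). Compound 3 gives > 100000 nM, which is a limit of the assay and not a number. So the larger group on the amide nitrogen, shared by compound 2 and compound 3, does not by itself give a measurable number here, and the ring on the carbonyl side matters, while the true size of the step stays unknown and could be larger than printed: the limit of > 100000 nM in this assay, at which 2 of the 3 values shown sit.

The hydroxyl and the bromine leave in the same step in which the methoxy enters, so the compounds shown cannot tell which part of the swap accounts for the loss. A 2-hydroxyphenyl or a 3-bromo-2-methoxyphenyl on the same carbonyl carbon would pull the change apart, and a 2-aminophenyl or a 3-chloro-2-hydroxyphenyl would test how closely the hydroxyl and the bromine can be replaced.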